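The source may report more compounds than this note shows. Statements on the series, on what has been measured and on what is new or still open speak of the compounds shown alone.

Among the measured compounds shown here, compound 1 `O=C(CCCCCCN(Cc1ccc(F)cc1)c1ncc(C(=O)NCCCn2ccnc2)s1)NO` is one of three compounds measured in a functional assay on A549 cells (Homo sapiens) for inhibition, read by MTT assay, with a stated time of 72 h (on this read-out higher numbers stand for weaker inhibition and lower numbers for stronger inhibition), where compound 1 gives 9700 nM. Compound 2 `O=C(CCCCCCCN(Cc1ccc(F)cc1)c1ncc(C(=O)NCCCn2ccnc2)s1)NO` gives 6600 nM, and the step of a 1.5-fold lower number from compound 1 to compound 2 (0.17 log units; within the scatter) lies within the scatter. Compound 3 `O=C(CCCCCCN(Cc1ccc(F)cc1)c1ncc(C(=O)NCc2cccnc2)s1)NO` gives 22000 nM, and the step of a 2.3-fold higher number from compound 1 to compound 3 (0.36 log units; beyond the scatter) is modest but beyond the scatter. Compound 1 thus stands second highest of the three numbers, close to compound 2 and furthest from compound 3.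

Compound 4 `CC(C)CCN(CCCCCCC(=O)NO)c1ncc(C(=O)NCCCn2ccnc2)s1` has not yet been measured. It differs from compound 1 in a single place: isobutyl in place of 4-fluorophenyl on a saturated chain carbon bound to a nitrogen on an aromatic ring. Neither measured step bears directly on this change. The step from compound 1 to compound 2 alters only the chain that carries the hydroxycarbamoyl group, and the step from compound 1 to compound 3 alters only the group on the amide-type nitrogen; the group on the saturated chain carbon bound to the nitrogen on the aromatic ring is the same in all three measured compounds. There is therefore no measured basis for expecting a step in either direction beyond the scatter, and the estimate rests on compound 1 alone. Compound 4 is accordingly expected to give about 12000 nM, with a range from 4000 nM to 40000 nM. The expected step is a 1.2-fold higher number from compound 1 to compound 4 (0.09 log units; within the scatter), which need not exceed the scatter.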

Compound 4, half-maximal inhibitory concentration: 5200 nM
Beside the measured number, compound 4's estimate is 2.3-fold (0.36 log units) above it, and the stated range covers the measured number.
By their numbers in this assay, from the lowest: compounds 4, 2 and 1 (each within the scatter of the next); then compound 3.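

In this assay, among the compounds shown here, isobutyl in place of 4-fluorophenyl on a saturated chain carbon bound to a nitrogen on an aromatic ring gives a 1.9-fold lower number from compound 1 to compound 4 (0.27 log units; within the scatter), the first reading at this place, since compounds 1, 2 and 3 all carry the same 4-fluorobenzyl group there. A group with one six-membered aromatic ring of carbon only gives way to one with no ring and no fluorine, and this assay does not separate compound 4 from compound 1, so here the ring is not needed to stay within the scatter of compound 1. No measured evidence on the cause of this result is at hand.

Because the ring and the fluorine leave together, the step cannot say what either contributes alone, and a plain benzyl group, an amine or a carboxylic acid at this place would be needed to tell how far the tolerance reaches. As far as these compounds go, it also stays open whether isopentyl would read the same alongside the longer chain of compound 2 or the pyridin-3-yl group of compound 3.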